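A few compounds are considered here, and "the series" means these few. Any claim that something is new, unique, unknown or untested is made for them only; others in the source may bear on it.

Compound 3 `COc1ccc(-c2cc(C(=O)Nc3ccc(Oc4ccnc5[nH]ccc45)cc3)ncn2)cc1` is the one of the two numbered compounds here that gives the lower reading in a functional assay on PC-3 cells (Homo sapiens) for cytotoxicity, read by MTT assay, with a stated time of 72 h (on this read-out higher numbers stand for weaker inhibition and lower numbers for stronger inhibition), where compound 3 gives 9830 nM. Its nearest neighbour is compound 1 `COc1ccc(-c2ccnc(C(=O)Nc3ccc(Oc4ccnc5[nH]ccc45)cc3)n2)cc1`, which in this assay gives 17300 nM, a gap within the scatter. Compound 2 `O=C(Nc1ccc(Oc2ccnc3[nH]ccc23)cc1)c1nccc(-c2ccc(Cl)cc2)n1` carries chloro where compound 1 carries methoxy. In this assay compound 2 is reported as "not active" (no number reported), without a number. Compound 4 `O=C(Nc1ccc(Oc2ccnc3[nH]ccc23)cc1)c1cc(-c2ccc(F)cc2)ncn1` differs from compound 3 by fluoro in place of methoxy on an aromatic carbon. For the measured compounds named here, no measured step of this kind exists on the shared core; given that compound 2 gives "not active" (no number reported), a small move towards weaker inhibition is expected, as a 2.0-fold higher number from compound 3 to compound 4 (0.31 log units; beyond the scatter). Compound 4 is therefore estimated at 20000 nM, between 7000 nM and 60000 nM.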

Compound 4, half-maximal inhibitory concentration: "not active" (no number reported)
Compound 4: no number reported; the estimate stays without a comparison.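

For the compounds shown here, compound 4 is reported in this assay without a number, so no step from compound 3 to compound 4 can be read. The compounds shown leave open how 4-methoxyphenyl and 4-fluorophenyl compare numerically on this core. No supporting evidence bears on this result.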